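The compounds below may be only part of what the source reports. "The series", "measured", "known", "first", "only" and "open" are said of these compounds alone.

Measured compounds:
- compound 1, `O=C(O)c1cn(C2CC2)c2cc(N3CCCC3)c(F)cc2c1=O`, in a functional assay on V79 cells (Cricetulus griseus) for cytotoxicity, read by colony formation (on this read-out higher numbers stand for weaker inhibition and lower numbers for stronger inhibition), compound 1 gives 38 ug/mL
- compound 2, `O=C(O)c1cn(C2CC2)c2c(F)c(N3CCCC3)c(F)cc2c1=O`, in this assay compound 2 gives 120 ug/mL
- compound 3, `CNCC1(C)CCN(c2cc3c(cc2F)c(=O)c(C(=O)O)cn3C2CC2)C1`, in this assay compound 3 gives 205 ug/mL

Compound 3 has the highest number of the three; against compound 2 the gap is within the scatter, against compound 1 it is beyond it. The two cores differ as set out in 3-methyl-3-((methylamino)methyl)pyrrolidin-1-yl in place of pyrrolidin-1-yl on an aromatic carbon, and that change gave a 5.4-fold higher number from compound 1 to compound 3 (0.73 log units; beyond the scatter).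

The change of interest is fluoro in place of hydrogen on an aromatic carbon, which produced a 3.2-fold higher number from compound 1 to compound 2 (0.50 log units; beyond the scatter). The same kind of change is now applied to compound 3 to give compound 4, `CNCC1(C)CCN(c2c(F)cc3c(=O)c(C(=O)O)cn(C4CC4)c3c2F)C1`, not yet measured; the change is fluoro in place of hydrogen on an aromatic carbon. The surroundings are not identical: in compound 1 the place is ortho to a pyrrolidin-1-yl group (5 heavy atoms), in compound 3 it is ortho to a 3-methyl-3-((methylamino)methyl)pyrrolidin-1-yl group (9 heavy atoms); the rest of the place description agrees.

For compound 4 in this assay a step of about the same size as the earlier one is expected, that is a 2.7-fold higher number from compound 3 to compound 4 (0.43 log units; beyond the scatter), resting on one precedent only, the step of a 3.2-fold higher number from compound 1 to compound 2 (0.50 log units; beyond the scatter), carried over to compound 3 with its value 205 ug/mL. With a single precedent and a different neighbouring group, the range is kept wide. The estimate for compound 4 is 550 ug/mL, expected to fall between 250 ug/mL and 1300 ug/mL.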

Compound 4, half-maximal inhibitory concentration: 8 ug/mL
Estimate against measurement, compound 4: 69-fold (1.84 log units) above; measured number below the stated range.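

In this assay, fluoro in place of hydrogen on an aromatic carbon gave a 26-fold lower number from compound 3 to compound 4 (1.41 log units; beyond the scatter), so the change did not carry over from the core of compound 1 to the core of compound 3 and its direction reversed: the same change on two cores in this assay, a 3.2-fold higher number (0.50 log units; beyond the scatter) from compound 1 to compound 2 and a 26-fold lower number (1.41 log units; beyond the scatter) from compound 3 to compound 4, 81-fold (1.91 log units) apart, beyond the scatter of two such steps

Read along the other edge of the same set, 3-methyl-3-((methylamino)methyl)pyrrolidin-1-yl in place of pyrrolidin-1-yl gave a 15-fold lower number from compound 2 to compound 4 (1.18 log units; beyond the scatter), which likewise differs from the step for this change without the added fluoro: the same change on two cores in this assay, a 5.4-fold higher number (0.73 log units; beyond the scatter) from compound 1 to compound 3 and a 15-fold lower number (1.18 log units; beyond the scatter) from compound 2 to compound 4, 81-fold (1.91 log units) apart, beyond the scatter of two such steps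

Both comparisons rest on the same four compounds and so form a single observation: in this set the two changes do not add, and the size and direction of each depend on whether the other is present, but this does not show why, nor how far it extends beyond these compounds.

The compounds shown leave open whether the reversal is tied to 3-methyl-3-((methylamino)methyl)pyrrolidin-1-yl or would also appear with another amine at that place, such as piperazin-1-yl. They also leave open whether it is specific to fluoro or would recur with chloro or methoxy in place of that hydrogen.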